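Swapping the amide group: from fluoropyridine to sulfamoylphenyl

The source may report more compounds than this note shows. Statements on the series, on what has been measured and on what is new or still open speak of the compounds shown alone.

Compound 1 (`CC(C)n1ncc2c(C(=O)Nc3ccc(F)cc3F)cc(-c3cccs3)nc21`): > 200000 nM (a limit of the assay)
Compound 2 (`CC(C)n1ncc2c(C(=O)Nc3cc(F)ccc3F)cc(-c3cccs3)nc21`): 100000 nM
Compound 3 (`CC(C)n1ncc2c(C(=O)Nc3ccc(F)cn3)cc(-c3cccs3)nc21`): > 200000 nM (a limit of the assay)

All three results come from an ADME assay on LLC-MK2 cells (Macaca mulatta) for cytotoxicity, read by spectrophotometry and crystal violet staining, with a stated time of 4 days (on this read-out lower numbers stand for higher toxicity in this test and higher numbers for lower toxicity in this test), and share one core. Compound 3 has no number here, only the limit > 200000 nM of the assay. The top of the range is marked by the limit of > 200000 nM in this assay, at which 2 of the 3 values shown sit, and compound 1 is the other result held there. The step followed here leads to compound 4 (`CC(C)n1ncc2c(C(=O)Nc3ccccc3S(N)(=O)=O)cc(-c3cccs3)nc21`) and amounts to this change: 2-sulfamoylphenyl in place of 5-fluoropyridin-2-yl on an amide-type nitrogen. Going by the values given here, three measured steps bear on it, all at that same nitrogen. They are an at least 2.0-fold lower number from compound 1 to compound 2 (0.30 log units; that floor lies within the scatter) and an at least 2.0-fold higher number from compound 2 to compound 3 (0.30 log units; that floor lies within the scatter) and also a step that the two limits leave unreadable from compound 1 to compound 3 as the third. None of them is shown to go beyond the scatter, yet none of the measured compounds carries 2-sulfamoylphenyl. Among the compounds with values here, compound 2, at 100000 nM, is the only true number to lean on. A change of no more than the scatter is therefore expected, or a modest fall in the number, and another limit reading remains quite possible. The estimated step is an at least 1.3-fold lower number from compound 3 to compound 4 (0.12 log units; that floor lies within the scatter) in this reading. For compound 4 the expected value is 150000 nM with an estimated range from 50000 nM to 300000 nM in this assay.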

Compound 4, half-maximal cytotoxic concentration: 25000 nM
Estimate against measurement, compound 4: 6.0-fold (0.78 log units) above; the whole stated range lies above it.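

In this assay, going by these compounds alone, 2-sulfamoylphenyl on the amide-type nitrogen gives the first steps at this position that clearly pass the scatter, whereas the earlier changes among the fluorinated aromatic groups showed none that did: an at least 8.0-fold lower number from compound 3 to compound 4 (0.90 log units; beyond the scatter), and an at least 8.0-fold lower number from compound 1 to compound 4 (0.90 log units; beyond the scatter). Within the data shown here, measured against the only earlier true number, the change gives a 4.0-fold lower number from compound 2 to compound 4 (0.60 log units; beyond the scatter), and this is the one step of the three with a size that can be read in full, so the position does respond in this test when this group enters. The other two steps are only floors, and their true size may be larger, because compound 1 and compound 3 both sit at the top of the range: the limit of > 200000 nM in this assay, at which 2 of the 4 values shown sit.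

On these data alone, what remains open is whether the fall in the number belongs to the sulfamoyl group itself or simply to the loss of the fluorine-bearing rings, since the group differs from all three earlier ones in more than one feature. A plain phenyl, or a phenyl carrying a methylsulfonyl group or a carboxylic acid in place of the sulfamoyl group, would be needed to separate these readings.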